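The compounds below may be only part of what the source reports. "The series", "measured", "known", "first", "only" and "open" are said of these compounds alone.

Measured compounds in an ADME assay on COLO 205 cells (Homo sapiens) for cytotoxicity, read by sulforhodamine B assay, with a stated time of 24 h; a lower number here means that less compound is tolerated, a higher number that more compound is tolerated:
compound 1 `COc1ccc(C(=O)/C=C/c2cc3ccccc3[nH]c2=O)cc1` — 77600 nM
compound 2 `O=C(/C=C/c1cc2ccccc2[nH]c1=O)c1ccc(O)cc1` — 76800 nM

Compound 2 gives the lowest of the two numbers in this assay, but its nearest neighbour is compound 1, and the step of a 1.0-fold lower number from compound 1 to compound 2 (0.00 log units; within the scatter) lies within the scatter, so the two compounds cannot be told apart on these numbers.

The next compound, compound 3 `O=C(/C=C/c1cc2ccccc2[nH]c1=O)c1ccc(Cl)cc1`, is compared with compound 2. The structural change is chloro in place of hydroxy on an aromatic carbon; the group sits on an aromatic carbon of a six-membered aromatic ring of carbon only, para to a large group, and cut one bond further out the change reads 4-hydroxyphenyl to 4-chlorophenyl.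

Among the measured compounds shown here, only one measured step touches this position, a 1.0-fold lower number from compound 1 to compound 2 (0.00 log units; within the scatter), which swapped hydrogen for methyl on the oxygen without a change beyond the scatter. For the measured compounds named here, no measured step replaces the oxygen itself by chlorine, so there is no direct precedent. On that basis a step of a 1.1-fold lower number from compound 2 to compound 3 (0.04 log units; within the scatter) is expected, that is, no change beyond the scatter. Compound 3 is therefore estimated at 70000 nM, with a range from 30000 nM to 160000 nM.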

Compound 3, concentration lethal to 50% of the cells: > 100000 nM
Compound 3: a limit, no number (the forecaster's own chance of this, stated with the estimate: 15%); at least 1.4-fold (0.15 log units) between middle value and limit.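

In this assay compound 3 gives > 100000 nM, which is a limit of the assay and not a number. The earlier step changed only what sat on the oxygen, whereas here the oxygen itself leaves, and with hydroxy goes the hydrogen-bond donor and acceptor counted for it: this reads as an at least 1.3-fold higher number from compound 2 to compound 3 (0.11 log units; that floor lies within the scatter), and chloro in place of methoxy reads as an at least 1.2-fold higher number from compound 1 to compound 3 (0.11 log units; that floor lies within the scatter). Both floors lie within the scatter, so hydroxy, methoxy and chloro at this position have so far produced no step printed as beyond it, but the true size of the two new steps remains unknown because the result for compound 3 is a limit: the limit of > 100000 nM in this assay, at which 1 of the 3 values shown sits.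

On these data alone, whether compound 3 truly differs from compound 1 and compound 2 therefore stays open, since its result gives a floor for each step and no upper bound. Also open, as far as these compounds go, is how an amine, a carboxylic acid or a longer chain in this place would read in this assay, and whether any such group would give a step beyond the scatter.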